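Working notes: from compound 2 to compound 3

The source may hold more compounds than are shown below. What is called first, only, known or untested is meant among the compounds shown, and "the series" means these compounds.

Measured so far in a physicochemical assay for lipophilicity, read by HPLC, measured as chromatographic lipophilicity; on this read-out lower numbers stand for lower lipophilicity and higher numbers for higher lipophilicity:
- compound 1 `CCC/N=C1\S/C(=C\c2ccc(C(=O)O)cc2)C(=O)N1c1ccccc1C` reads 1
- compound 2 `CCC/N=C1\S/C(=C\c2ccc(C(=O)OCCCO)cc2)C(=O)N1c1ccccc1O` reads 2.3

Of these two numbers, compound 2 stands highest at 2.3, with compound 1 lower by more than the scatter. Compound 3 `CCC/N=C1\S/C(=C\c2ccc(CCC(=O)OC)cc2)C(=O)N1c1ccccc1O` has not yet been measured in this assay. Its structural change is 2-(methoxycarbonyl)ethyl in place of (3-hydroxypropoxy)carbonyl on an aromatic carbon, with 2-(methoxycarbonyl)ethyl in place of (3-hydroxypropoxy)carbonyl on an aromatic carbon, para to a large group. Going by the values given here, no measured pair differs in one place, so no measured step guides this estimate, and the expectation rests on the structural change alone. An upward move beyond the scatter is expected, estimated as a number 0.60 log units higher from compound 2 to compound 3 (beyond the scatter). The expected value for compound 3 is 2.9, with an estimated range of 2.4 to 3.4.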

Compound 3, distribution coefficient: 3.5
The estimate for compound 3 lay 0.60 log units below the measured number; the whole stated range lies below it.
By their numbers in this assay, from the lowest: compound 1; then compound 2; then compound 3.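

In this assay, 2-(methoxycarbonyl)ethyl in place of (3-hydroxypropoxy)carbonyl on an aromatic carbon, para to a large group, gives a large step (a number 1.20 log units higher from compound 2 to compound 3 (beyond the scatter)). Going by these compounds alone, this is the first reading of this position alone, since compound 1 and compound 2 differ in more than one place. The exchange replaces a group with 1 hydrogen-bond donor and 3 hydrogen-bond acceptors by one with 0 donors and 2 acceptors, but nothing available explains the size of the step.

Which part of the exchange carries the step remains open, as the two groups differ in both their chain and their ester. Also open, from the compounds shown here alone, is how a carboxylic acid on a two-carbon chain, or an amine, would read at this position in this assay.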